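Methyl on the core: expected step for compound 4

This account rests on a few compounds, and the source may have more. Where it says the series, first, only, none or still open, it means among the compounds named here.

In an assay for binding affinity to Indoleamine 2,3-dioxygenase 1 (Homo sapiens), read by spectrophotometry, with a stated time of 30 min (a higher number here means weaker binding, a lower number tighter binding), compound 1 `Cc1cc([Si](C)(C)C)c2cn[nH]c2c1` gives 2500 nM, compound 2 `C[Si](C)(C)c1cccc2[nH]ncc12` gives 150000 nM, and compound 3 `OC(Cc1ccccc1)c1cccc2[nH]ncc12` gives 31000 nM, the second highest of the three numbers, closer to the number of compound 2 than to that of compound 1. Compound 4 `Cc1cc(C(O)Cc2ccccc2)c2cn[nH]c2c1` differs from compound 3 by methyl in place of hydrogen on an aromatic carbon. Within the data shown here, one measured step bears directly on this change: a 60-fold higher number from compound 1 to compound 2 (1.78 log units; beyond the scatter), which is the same methyl removed from the same place on the core. Read in the opposite direction, that step points to a markedly lower number when the methyl is present. Among the measured compounds shown here, the step from compound 3 to compound 4 is therefore expected to be a large drop in this assay, of about a 39-fold lower number from compound 3 to compound 4 (1.59 log units; beyond the scatter), though only one such pair supports it, so the range is kept wide. Compound 4 is accordingly estimated at 800 nM, with a range from 150 nM to 5000 nM.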

Compound 4, dissociation constant: 1200 nM
Compound 4: the middle estimate sits 1.5-fold (0.18 log units) below what was measured; measured number inside the range.
By their numbers in this assay, from the lowest: compound 4; then compound 1; then compound 3; then compound 2.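

In this assay, methyl in place of hydrogen on the aromatic carbon gives a 26-fold lower number from compound 3 to compound 4 (1.41 log units; beyond the scatter), a large step on a second core. Until now, the effect of this methyl rested on a single pair, so it could have belonged to that pair alone. It now appears with two different groups at the same place, and the size of the step carries over between them: the same change on two cores in this assay, a 60-fold higher number (1.78 log units; beyond the scatter) from compound 1 to compound 2 and a 26-fold higher number (1.41 log units; beyond the scatter) from compound 4 to compound 3, 2.3-fold (0.37 log units) apart, within the scatter of two such steps.

The compounds shown carry only hydrogen or methyl at this position, so it remains open whether ethyl, methoxy or chlorine there would lower the number further or raise it. Also open, going by these compounds, is whether the step would persist if the hydroxyl of compound 4 gave way to an amine or a carboxylic acid.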